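This account rests on a few compounds, and the source may have more. Where it says the series, first, only, none or still open, it means among the compounds named here.

Compound 1 `Nc1scc(CN2CCN(c3ccc(Cl)cc3Cl)CC2)c1C(=O)c1ccc(Cl)cc1` and compound 2 `Nc1scc(CN2CCN(c3ccc(Cl)cc3F)CC2)c1C(=O)c1ccc(Cl)cc1` share one core and differ in a single aromatic substituent. In a functional assay on CHO cells with adenosine receptor A1 (Homo sapiens) as the target, read by cAMP accumulation and immunoassay, with a stated time of 6 min, tested at 1 uM (on this read-out lower numbers stand for a stronger effect and higher numbers for a weaker effect at the one concentration tested), compound 1 gives -54%. In this assay compound 2 gives -57%, and the step of a number 3 percentage points lower from compound 1 to compound 2 (within the scatter) shows that fluoro in place of chloro on an aromatic carbon left the read-out essentially unchanged. Compound 2 thus holds the lower of the two numbers, but its gap to compound 1 lies within the scatter, so no order can be claimed. Compound 3 `COc1ccc(N2CCN(Cc3csc(N)c3C(=O)c3ccc(Cl)cc3)CC2)cc1` differs from compound 2 by 4-methoxyphenyl in place of 4-chloro-2-fluorophenyl on an amine nitrogen in a ring. Among the compounds with values here, no measured step bears directly on this exchange: the only step available, a number 3 percentage points lower from compound 1 to compound 2 (within the scatter), swapped two halogens on the same ring and stayed within the scatter, whereas here the entire 4-chloro-2-fluorophenyl is replaced by 4-methoxyphenyl. Because compound 2 gives -57%, compound 3 is expected to remain in the same region, with a step of a number 12 percentage points higher from compound 2 to compound 3 (beyond the scatter) in this assay. Compound 3 is therefore estimated at -45%, between -75% and -10%.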

Compound 3, a percentage reported as activity, at one concentration (the size of the read-out at that concentration, not a potency): -15%
Beside the measured number, compound 3's estimate is 30 percentage points below it, and the stated range covers the measured number.
By their numbers in this assay, from the lowest: compounds 2 and 1 (each within the scatter of the next); then compound 3.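

In this assay the group on the amine nitrogen in the ring proves able to move the read-out: 4-methoxyphenyl in place of 4-chloro-2-fluorophenyl gives a number 42 percentage points higher from compound 2 to compound 3 (beyond the scatter) in this comparison, and 4-methoxyphenyl in place of 2,4-dichlorophenyl gives a number 39 percentage points higher from compound 1 to compound 3 (beyond the scatter) on the same scale. Fluoro in place of chloro had shown no such sensitivity, whereas this exchange of the whole aryl group shifts the result towards a weaker effect at the one concentration tested. Nothing available explains this shift.

The compounds shown leave open whether the step follows the arrival of the methoxy group or the departure of the halogens, as the two change together here. An unsubstituted phenyl or a 4-chlorophenyl at this place would separate the two.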